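Swapping the nitro for a phenyl on the amide ring

The source may report more compounds than this note shows. Statements on the series, on what has been measured and on what is new or still open speak of the compounds shown alone.

Three compounds share one core, an amide-linked aromatic ring that carries a single group on its outer position. Compound 1 `O=C(Nc1cccc(-c2oc3cc(-c4ccc(F)cc4)ccc3c(=O)c2O)c1)c1ccc(Cl)cc1` carries a chloro and in a functional assay on MCF7 cells (Homo sapiens) for antiproliferative activity, read by CCK-8 assay, with a stated time of 72 h (on this read-out lower numbers stand for stronger inhibition and higher numbers for weaker inhibition), compound 1 gives 4730 nM. Compound 2 `O=C(Nc1cccc(-c2oc3cc(-c4ccc(F)cc4)ccc3c(=O)c2O)c1)c1ccc(C(F)(F)F)cc1` carries a trifluoromethyl and in this assay compound 2 gives 32600 nM. Compound 3 `O=C(Nc1cccc(-c2oc3cc(-c4ccc(F)cc4)ccc3c(=O)c2O)c1)c1ccc([N+](=O)[O-])cc1` carries a nitro and in this assay compound 3 gives 3970 nM, the lowest of the three numbers, though compound 3 and compound 1 sit within the scatter of each other (a 1.2-fold lower number from compound 1 to compound 3 (0.08 log units; within the scatter)). Going by the values given here, the only steps beyond the scatter are a 6.9-fold higher number from compound 1 to compound 2 (0.84 log units; beyond the scatter) and an 8.2-fold lower number from compound 2 to compound 3 (0.91 log units; beyond the scatter).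

Compound 4 `O=C(Nc1cccc(-c2oc3cc(-c4ccc(F)cc4)ccc3c(=O)c2O)c1)c1ccc(-c2ccccc2)cc1` differs from compound 3 by phenyl in place of nitro on an aromatic carbon. Among the compounds with values here, no measured step involves a phenyl at this position, so the bearing of the earlier steps is indirect: the chloro and nitro gave numbers within the scatter of each other, while the trifluoromethyl raised the number modestly. A phenyl is expected to behave more like the trifluoromethyl, so a modest rise is estimated, a 2.3-fold higher number from compound 3 to compound 4 (0.36 log units; beyond the scatter). Compound 4 is expected to give 9000 nM, within a range of 3000 nM to 30000 nM.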

Compound 4, half-maximal inhibitory concentration: 38500 nM
Beside the measured number, compound 4's estimate is 4.3-fold (0.63 log units) below it, and the stated range ends below it.
By their numbers in this assay, from the lowest: compounds 3 and 1 (each within the scatter of the next); then compounds 2 and 4 (each within the scatter of the next).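

In this assay this position does not accept phenyl the way it accepts nitro or chloro, with a 9.7-fold higher number from compound 3 to compound 4 (0.99 log units; beyond the scatter) and also an 8.1-fold higher number from compound 1 to compound 4 (0.91 log units; beyond the scatter) for the same swap on the amide ring. Phenyl and trifluoromethyl instead sit together, with a 1.2-fold higher number from compound 2 to compound 4 (0.07 log units; within the scatter) between them, so the four groups form two levels, chloro with nitro and trifluoromethyl with phenyl, and a group bearing a ring ends up on the same level as one without a ring. Nothing at hand says why the groups divide this way.

The compounds shown leave open where a methyl, an amine or a carboxylic acid at this position would fall between the two levels. They also leave open whether a longer chain, or a phenyl carrying a group of its own, would stay on the upper level.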